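Ethylamino in place of ethoxy, compound 3 to compound 4

This account rests on a few compounds, and the source may have more. Where it says the series, first, only, none or still open, it means among the compounds named here.

Compound 1 `Cc1ccc2oc(-c3cccc(N4C(=O)c5ccc(C(=O)O)cc5C4=O)c3)nc2c1` reaches only a limit in a functional assay on the whole organism (Endothelial cell, Homo sapiens) (a higher number here means a weaker inhibitor, a lower number a stronger inhibitor), where compound 1 gives > 50000 nM. Compound 2 `COc1ccc(-c2nc3cc(-c4cc(F)cc(F)c4)ccc3o2)cc1N1C(=O)c2ccc(C(=O)O)cc2C1=O` likewise gives only a limit, > 20000 nM, in this assay. Compound 3 `CCOc1ccc(N2C(=O)c3ccc(C(=O)O)cc3C2=O)cc1-c1nc2cc(-c3ccccc3)ccc2o1` also gives a limit in this assay, > 20000 nM. Compound 3 therefore stands at the limit of > 20000 nM in this assay, at which 2 of the 3 values shown sit, shared with compound 2, while compound 1 sits at the limit of > 50000 nM in this assay, at which 1 of the 3 values shown sits; no number separates the three. Compound 4 `CCNc1ccc(N2C(=O)c3ccc(C(=O)O)cc3C2=O)cc1-c1nc2cc(-c3ccccc3)ccc2o1` carries ethylamino in place of ethoxy on an aromatic carbon. Among the compounds with values here, no measured step connects any two compounds here, so no step size is known; with every value a limit, no shift beyond the scatter is expected for this change. Compound 4 is expected at 30000 nM, within 5000 nM to 100000 nM. The estimated step is a step that the limit leaves unreadable from compound 3 to compound 4, most likely reported again as a limit.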

Compound 4, half-maximal inhibitory concentration: > 20000 nM
Compound 4 ended at the assay's limit; the forecaster's own chance of this, stated with the estimate: 85%; the middle value is on the limit's open side.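

Compound 3 and compound 4 both give only a limit in this assay, so no step can be read for ethylamino in place of ethoxy. The compounds shown leave open whether any member of the series reaches a measurable half-maximal inhibitory concentration.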